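The compounds below may be only part of what the source reports. "The series", "measured", "known", "first", "only" and "open" are said of these compounds alone.

Compound 1 `O=C(C1=C(O)C(=O)N(CCCn2ccnc2)C1c1ccc(Br)cc1)c1ccccc1` gives 31600 nM in a functional assay on SAOS-2 cells (Homo sapiens) for antiproliferative activity, read by MTT assay, with a stated time of 72 h; on this read-out lower numbers stand for stronger inhibition and higher numbers for weaker inhibition.
Compound 2 `O=C(C1=C(OC2CCCCC2)C(=O)N(CCCn2ccnc2)C1c1ccc(Br)cc1)c1ccccc1` gives 29700 nM in this assay.
Compound 3 `NC1=C(C(=O)c2ccccc2)C(c2ccc(Br)cc2)N(CCCn2ccnc2)C1=O` gives 107000 nM in this assay.

Compound 2 carries the lowest number of the three, but the gap is only a 1.1-fold lower number from compound 1 to compound 2 (0.03 log units; within the scatter), so compound 1 and compound 2 cannot be told apart; only compound 3 stands clearly apart, by a 3.6-fold higher number from compound 2 to compound 3 (0.56 log units; beyond the scatter). Compound 4 `O=C(C1=C(Nc2ccc(Cl)cc2)C(=O)N(CCCn2ccnc2)C1c1ccc(Br)cc1)c1ccccc1` differs from compound 2 in a single place: (4-chlorophenyl)amino in place of cyclohexyloxy on a double-bonded ring carbon. Among the measured compounds shown here, two measured steps touch this position. Enlarging the oxygen-linked group from hydrogen to cyclohexyl changed nothing beyond the scatter, as shown by a 1.1-fold lower number from compound 1 to compound 2 (0.03 log units; within the scatter). Exchanging the oxygen-linked group for a bare amino group, by contrast, cost a modest amount, with a 3.4-fold higher number from compound 1 to compound 3 (0.53 log units; beyond the scatter) and a 3.6-fold higher number from compound 2 to compound 3 (0.56 log units; beyond the scatter). For the measured compounds named here, compound 4 again puts a nitrogen at this position, now carrying a 4-chlorophenyl group, and no measured compound shows what an aryl group on that nitrogen does. A modest weakening is therefore expected in this assay, smaller than a full shift to the level of compound 3, with a wide range. Compound 4 is estimated at 45000 nM, between 15000 nM and 130000 nM, which is expected to correspond to a 1.5-fold higher number from compound 2 to compound 4 (0.18 log units; within the scatter).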

Compound 4, half-maximal inhibitory concentration: 24800 nM
The estimate for compound 4 lay 1.8-fold (0.26 log units) above the measured number, within the range that was stated.
By their numbers in this assay, from the lowest: compounds 4, 2 and 1 (each within the scatter of the next); then compound 3.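

Having a nitrogen at this position does not in itself go with the higher number of compound 3: in this assay, adding 4-chlorophenyl to the amine nitrogen gives a 4.3-fold lower number from compound 3 to compound 4 (0.63 log units; beyond the scatter) and is a modest step beyond the scatter. The new group also proves interchangeable with the two oxygen-linked groups on this read-out, since replacing cyclohexyloxy gives a 1.2-fold lower number from compound 2 to compound 4 (0.08 log units; within the scatter) and replacing hydroxy gives a 1.3-fold lower number from compound 1 to compound 4 (0.11 log units; within the scatter) and both steps lie within the scatter. Three quite different groups, hydroxy, cyclohexyloxy and (4-chlorophenyl)amino, therefore cannot be told apart here, and among these four compounds only the bare amino group of compound 3 stands apart.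

No supporting measurement is available to explain why the aryl-bearing nitrogen and the bare amino group differ. Also open, going by these compounds, is which part of the new group matters, which a phenylamino group without the chlorine or a cyclohexylamino group on the same core would help to separate.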